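The source may report more compounds than this note shows. Statements on the series, on what has been measured and on what is new or still open speak of the compounds shown alone.

In an ADME assay on HepG2 2.2.15 cells (Homo sapiens) for cytotoxicity, read by MTT assay, with stated times of 48 h and 9 days (on this read-out higher numbers stand for lower toxicity in this test and lower numbers for higher toxicity in this test), compound 1 `O=C(/C=C/c1coc2cc(O)ccc2c1=O)NCc1ccc(F)cc1` gives 357000 nM, the lowest of the three numbers recorded. Its nearest neighbour is compound 3 `COc1ccc2c(=O)c(/C=C/C(=O)Nc3ccccc3)coc2c1`, which gives 523000 nM, a gap that sits within the usual scatter, so the two cannot be told apart. The furthest is compound 2 `COc1ccc2c(=O)c(/C=C/C(=O)Nc3cccc(Cl)c3)coc2c1`, which gives 1100000 nM, a gap that does lie beyond the scatter.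

Compound 4 `Cc1ccccc1NC(=O)/C=C/c1coc2cc(O)ccc2c1=O` is still unmeasured. It differs from compound 1 in one place: 2-methylphenyl in place of 4-fluorobenzyl on an amide-type nitrogen. Among the compounds with values here, the only measured step between neighbours, a 2.1-fold lower number from compound 2 to compound 3 (0.32 log units; beyond the scatter), concerns hydrogen in place of chloro on an aromatic carbon, a different kind of change made on compounds whose core also differs from that of compound 1. It therefore bears on the present step only loosely, showing that a single change on the aromatic ring attached to the amide nitrogen can move the number by a modest amount in either direction. Compounds 2 and 3, both carrying an aromatic ring directly on the amide nitrogen, show numbers not below that of compound 1.

On this basis a modest step upward is expected, a 1.4-fold higher number from compound 1 to compound 4 (0.15 log units; within the scatter), with wide uncertainty. Compound 4 is estimated to give 500000 nM, within a range from 180000 nM to 1400000 nM.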

Compound 4, half-maximal cytotoxic concentration: 374000 nM
Beside the measured number, compound 4's estimate is 1.3-fold (0.13 log units) above it; the range from low to high includes it.
By their numbers in this assay, from the lowest: compounds 1, 4 and 3 (each within the scatter of the next); then compound 2.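

In this assay, putting 2-methylphenyl in place of 4-fluorobenzyl on the amide-type nitrogen gives a 1.0-fold higher number from compound 1 to compound 4 (0.02 log units; within the scatter), so the two groups cannot be told apart at this position. Within the data shown here, the earlier step concerned only a chloro or a hydrogen on an aromatic ring, on compounds with a different core, whereas this is the first measured change of the whole group on the amide-type nitrogen of the core of compound 1. The swap removes the fluorine and brings in a methyl, and the group's ring is of the same kind on both sides, but a single step cannot show how each of these features counts on its own, and nothing measured here offers an explanation for the lack of separation.

Going by these compounds, all the groups at this position on this core carry a six-membered aromatic ring of carbon only, so it remains open whether the number would hold with a group lacking such a ring, such as a straight alkyl chain, an amine or a carboxylic acid. On these data alone, it is also open whether the same swap would leave the number unmoved on the core shared by compound 2 and compound 3.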